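Bromo to dimethylamino on the hindered phenol core

The compounds below may be only part of what the source reports. "The series", "measured", "known", "first", "only" and "open" are said of these compounds alone.

Compound 1 `CC(C)c1cc(Br)cc(C(C)C)c1O` gives 5.49 in a physicochemical assay for lipophilicity (on this read-out lower numbers stand for lower lipophilicity and higher numbers for higher lipophilicity), the higher of the two numbers in hand; compound 2 `CC(C)c1cc(CN(C)C)cc(C(C)C)c1O` gives 2.5. Within the data shown here, the one measured step, a number 2.99 log units lower from compound 1 to compound 2 (beyond the scatter), is large and downward. Compound 3 `CC(C)c1cc(N(C)C)cc(C(C)C)c1O` differs from compound 1 as follows: dimethylamino in place of bromo on an aromatic carbon. That step shares the loss of bromo with the step to compound 2, so a downward move is expected, though a smaller one than a number 2.99 log units lower from compound 1 to compound 2 (beyond the scatter), since the entering group is a different amine; the expected step is a number 0.99 log units lower from compound 1 to compound 3 (beyond the scatter). Compound 3 is therefore estimated at 4.5, in the range 3.6 to 5.4.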

Compound 3, partition coefficient: 4.52
For compound 3 the middle estimate is 0.02 log units below the measured one; the range from low to high includes it.
By their numbers in this assay, from the lowest: compound 2; then compound 3; then compound 1.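

At this position, para to a hydroxy group, bromo to dimethylamino is only a modest step in this assay (a number 0.97 log units lower from compound 1 to compound 3 (beyond the scatter)), so the large drop with (dimethylamino)methyl does not extend to every nitrogen-bearing group here. Exchanging (dimethylamino)methyl for dimethylamino on the same aromatic carbon is itself a large step (a number 2.02 log units higher from compound 2 to compound 3 (beyond the scatter)). Nothing in hand explains the gap between these two groups.

Open, going by these compounds, is where a longer chain ending in dimethylamino, such as (dimethylamino)ethyl, would fall on this read-out. A carboxylic acid or a methoxy group at this position also remains to be placed.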